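Swapping benzyl for isopropyl on the aryl oxygen

A few compounds are considered here, and "the series" means these few. Any claim that something is new, unique, unknown or untested is made for them only; others in the source may bear on it.

Measured so far:
Compound 1, `Cc1cc(-c2ccccc2)c(S(C)(=O)=O)cc1C(=O)N=C(N)N`, 19 nM
Compound 2, `Cc1cc(OCc2ccccc2)c(S(C)(=O)=O)cc1C(=O)N=C(N)N`, 28 nM

Both compounds were tested in a functional assay for inhibition of sodium/hydrogen exchanger (Oryctolagus cuniculus); a lower number here means a stronger inhibitor, a higher number a weaker inhibitor. Compound 2 has the higher of the two numbers, but the step of a 1.5-fold higher number from compound 1 to compound 2 (0.17 log units; within the scatter) is within the scatter, so the two are not distinguishable. The new compound 3, `Cc1cc(OC(C)C)c(S(C)(=O)=O)cc1C(=O)N=C(N)N`, differs from compound 2 by isopropyl in place of benzyl on an oxygen on an aromatic ring. Within the data shown here, the only step available, from compound 1 to compound 2, replaces one aromatic ring by a benzyloxy group and hardly moves the number; it does not remove a ring altogether, as the step to compound 3 does. Among the measured compounds shown here, there is no direct precedent for losing the aromatic ring, so the step of a 2.5-fold higher number from compound 2 to compound 3 (0.40 log units; beyond the scatter) is an expectation with a wide range, leaning toward a modestly higher number. Compound 3 is therefore estimated at 70 nM, between 20 nM and 250 nM.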

Compound 3, half-maximal inhibitory concentration: 19 nM
Beside the measured number, compound 3's estimate is 3.7-fold (0.57 log units) above it; measured number below the stated range.
By their numbers in this assay, from the lowest: compounds 1, 3 and 2 (each within the scatter of the next).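

Until now, both compounds carried a second aromatic ring at this place, so it was unclear whether potency depended on that ring. In this assay, the ring proves unnecessary: with isopropyl in place of benzyl on the oxygen, the result stays within the scatter (a 1.5-fold lower number from compound 2 to compound 3 (0.17 log units; within the scatter)), and the same holds with isopropoxy in place of phenyl on the aromatic carbon (no change at the digits printed from compound 1 to compound 3 (within the scatter)). No supporting data are available to explain why these groups can stand in for one another.

As far as these compounds go, the groups compared here contain only carbon and hydrogen apart from the linking oxygen, so whether this place also accepts an amine or a carboxylic acid remains open. Methyl or a longer chain such as n-butyl on the oxygen would show how far this freedom extends.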